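A few compounds are considered here, and "the series" means these few. Any claim that something is new, unique, unknown or untested is made for them only; others in the source may bear on it.

Measured compounds:
- compound 1, `Oc1cccc(-c2cc(-c3cccs3)cc(-c3ccccc3O)n2)c1`, in an assay on isolated protein for inhibition of DNA topoisomerase 1 (Homo sapiens), with a stated time of 30 min, tested at 100 uM (a higher number here means a stronger effect of the compound at the concentration tested, a lower number a weaker effect), gives 83.2%
- compound 2, `Oc1cccc(-c2cc(-c3ccsc3)cc(-c3ccccc3O)n2)c1`, in this assay gives 10.2%
- compound 3, `Oc1ccccc1-c1cc(-c2ccco2)cc(-c2ccccc2O)n1`, in this assay gives 89.1%

Compound 3 has the highest of the three numbers in this assay, yet its gap to compound 1 lies within the scatter, so the two cannot be ordered; only compound 2 is clearly separated from it, by a number well beyond the scatter. Among the compounds with values here, the one step measured between compounds that differ in a single place is a number 73 percentage points lower from compound 1 to compound 2 (beyond the scatter), and it concerns the exchange of one five-membered ring for another, not the hydroxyphenyl group.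

Compound 4, `Oc1cccc(-c2cc(-c3ccco3)cc(-c3ccccc3O)n2)c1`, differs from compound 3 in one place: 3-hydroxyphenyl in place of 2-hydroxyphenyl on an aromatic carbon. Within the data shown here, no measured step covers this exact change. Compound 1 and compound 3 differ in two places at once, one of them being this same hydroxyphenyl exchange, and their values sit within the scatter of each other; that is the only hint available, and it points to no shift. Compound 4 is therefore expected to stay close to compound 3, with a step of a number 4.1 percentage points lower from compound 3 to compound 4 (within the scatter), well inside the scatter. The estimate for compound 4 in this assay is 85%, with a range from 65% to 95%.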

Compound 4, a percentage reported as inhibition, at one concentration (the size of the read-out at that concentration, not a potency): 90.1%
Compound 4: the middle estimate sits 5.1 percentage points below what was measured, and the stated range covers the measured number.
By their numbers in this assay, from the lowest: compound 2; then compounds 1, 3 and 4 (each within the scatter of the next).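

In this assay, the exchange of 2-hydroxyphenyl for 3-hydroxyphenyl next to the ring nitrogen can now be read directly, as a number 1 percentage points higher from compound 3 to compound 4 (within the scatter), so with furan-2-yl on the shared core the two hydroxyphenyl groups cannot be told apart. With 3-hydroxyphenyl held in place, furan-2-yl in place of thiophen-2-yl comes to a number 6.9 percentage points higher from compound 1 to compound 4 (within the scatter), while furan-2-yl in place of thiophen-3-yl comes to a number 79.9 percentage points higher from compound 2 to compound 4 (beyond the scatter). Among these compounds, the large steps all involve compound 2, the only one carrying thiophen-3-yl, whereas furan-2-yl and thiophen-2-yl cannot be separated. Nothing at hand explains these numbers.

The compounds shown leave open whether the hydroxyphenyl exchange would be as silent with thiophen-3-yl on the core, and whether 4-hydroxyphenyl, an aminophenyl group or a carboxylic acid in that place would fit the same picture. Going by these compounds, each number is also a read-out at one concentration, so whether compound 1, compound 3 and compound 4 would show a stronger or weaker effect at any other concentration remains unknown.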